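Swapping methyl for trifluoromethyl on a nucleoside transporter inhibitor

The source may report more compounds than this note shows. Statements on the series, on what has been measured and on what is new or still open speak of the compounds shown alone.

Of the compounds shown here, three sharing one core have been measured in an assay on isolated protein for inhibition of Equilibrative nucleoside transporter 1 (Homo sapiens); a lower number here means a stronger inhibitor, a higher number a weaker inhibitor. Compound 3 `Cc1cccc(CSc2ncnc3c2ncn3[C@@H]2O[C@H](CO)[C@@H](O)[C@H]2O)c1` gives 16.2 nM, which is the lowest of the three numbers. Its nearest neighbour is compound 1 `OC[C@H]1O[C@@H](n2cnc3c(SCc4cccc(Cl)c4)ncnc32)[C@H](O)[C@@H]1O`, which in this assay gives 18.2 nM; the two differ by a 1.1-fold lower number from compound 1 to compound 3 (0.05 log units; within the scatter), so nothing separates them. Compound 2 `OC[C@H]1O[C@@H](n2cnc3c(SCc4ccccc4Br)ncnc32)[C@H](O)[C@@H]1O` stands furthest away and in this assay gives 151 nM, a gap described by a 9.3-fold lower number from compound 2 to compound 3 (0.97 log units; beyond the scatter) and, from the other side, by an 8.3-fold higher number from compound 1 to compound 2 (0.92 log units; beyond the scatter).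

Compound 4 `OC[C@H]1O[C@@H](n2cnc3c(SCc4cccc(C(F)(F)F)c4)ncnc32)[C@H](O)[C@@H]1O` has not been measured in this assay. It differs from compound 3 in one place: trifluoromethyl in place of methyl on an aromatic carbon. For the measured compounds named here, of the steps already seen, only the one from compound 1 to compound 3 touches the same aromatic carbon, and there an exchange of chloro for methyl gave a 1.1-fold lower number from compound 1 to compound 3 (0.05 log units; within the scatter), a change that stayed inside the scatter. The larger moves between compounds 1, 2 and 3 concern a different position and do not bear directly on this exchange. On that basis the step from compound 3 to compound 4 is expected to be small, a 1.2-fold higher number from compound 3 to compound 4 (0.09 log units; within the scatter), with no clear direction. Compound 4 is therefore estimated at 20 nM, within a range of 7 nM to 60 nM.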

Compound 4, inhibition constant: 19.1 nM
The estimate for compound 4 lay 1.0-fold (0.02 log units) above the measured number, within the range that was stated.
By their numbers in this assay, from the lowest: compounds 3, 1 and 4 (each within the scatter of the next); then compound 2.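

In this assay, replacing methyl with trifluoromethyl takes the group from one heavy atom to four, yet the step stays inside the scatter, with a 1.2-fold higher number from compound 3 to compound 4 (0.07 log units; within the scatter). The exchange of chloro for trifluoromethyl on the same aromatic carbon reads the same way, with a 1.0-fold higher number from compound 1 to compound 4 (0.02 log units; within the scatter), so the tolerance seen earlier only for chloro and methyl now extends to a group with more heavy atoms, and the three compounds cannot be separated in this assay. Compound 2 remains apart from this new compound too, with a 7.9-fold lower number from compound 2 to compound 4 (0.90 log units; beyond the scatter), so the gap that set the 2-bromophenyl compound apart from the 3-substituted compounds 1 and 3 also holds for the 3-(trifluoromethyl)phenyl compound.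

As far as these compounds go, it remains open whether an amine or a carboxylic acid on this aromatic carbon would be tolerated as well, and whether the gap to compound 2 comes from the bromine itself or from its place on the ring, since that step changes both at once. Nothing at hand speaks to why these three groups give indistinguishable readings.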